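Three inactive analogues and a fourth aryl variant

The source may hold more compounds than are shown below. What is called first, only, known or untested is meant among the compounds shown, and "the series" means these compounds.

The measured compounds are these. Compound 1 `N#CC1=C(N)Oc2c(c3nc4ccccc4nc3c3ccccc23)C12C(=O)N(Cc1cnnn1-c1ccccc1Cl)c1ccccc12` stands in a functional assay on HCT-116 cells (Homo sapiens) for antiproliferative activity, read by MTT assay, with a stated time of 48 h (on this read-out lower numbers stand for stronger inhibition and higher numbers for weaker inhibition), at > 50000 nM, a limit of the assay rather than a number. Compound 2 `N#CC1=C(N)Oc2c(c3nc4ccccc4nc3c3ccccc23)C12C(=O)N(Cc1cnnn1-c1cccc(Br)c1)c1ccccc12` stands in this assay at > 50000 nM, again a limit. Compound 3 `CCOc1ccc(-n2nncc2CN2C(=O)C3(C(C#N)=C(N)Oc4c3c3nc5ccccc5nc3c3ccccc43)c3ccccc32)cc1` stands in this assay at > 50000 nM, also a limit.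

Compound 2 therefore stands where every compound here stands: at the upper limit, with no measurable number of its own, and the two other values shown are limits as well (the limit of > 50000 nM in this assay, at which 3 of the 3 values shown sit). The steps between the measured compounds are all unreadable for that reason: a step that the two limits leave unreadable from compound 1 to compound 2, a step that the two limits leave unreadable from compound 1 to compound 3 and a step that the two limits leave unreadable from compound 2 to compound 3. All three exchange the aryl group on the aromatic nitrogen, and none of them lifted any compound off the limit.

Compound 4 `Cc1ccc(Cl)cc1-n1nncc1CN1C(=O)C2(C(C#N)=C(N)Oc3c2c2nc4ccccc4nc2c2ccccc32)c2ccccc21` continues the same kind of exchange, (5-chloro-2-methylphenyl in place of 3-bromophenyl on an aromatic nitrogen). Since the three measured steps on this position were each unreadable and every value sits at the limit, no change beyond the scatter can be anticipated in this assay, and the most probable outcome for compound 4 is another limit. Compound 4 is thus expected at about 80000 nM, within 40000 nM to 250000 nM. The step that the limit leaves unreadable from compound 2 to compound 4 is expected to remain unreadable.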

Compound 4, half-maximal inhibitory concentration: > 50000 nM
Compound 4: only a limit was reported (the forecaster's own chance of this, stated with the estimate: 85%); the middle value is on the limit's open side.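

In this assay compound 4 gives > 50000 nM, a limit and not a number. For the compounds shown here, its steps to compound 1, compound 2 and compound 3 therefore cannot be read, so no new step follows: the limit of > 50000 nM in this assay, at which 4 of the 4 values shown sit. The compounds shown leave open whether any aryl group on this aromatic nitrogen would give a measurable value in this assay.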